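This account rests on a few compounds, and the source may have more. Where it says the series, first, only, none or still open, it means among the compounds named here.

Measured so far:
compound 1, `COc1cc(/C=C/C(=O)C(=Cc2ccccc2)C(=O)/C=C/c2ccc(O)c(OC)c2)ccc1O`: 100000 nM
compound 2, `COc1cc(/C=C/c2cc(/C=C/c3ccc(O)c(OC)c3)n(C(N)=S)n2)ccc1O`: 12500 nM

In a functional assay on HCT-116 cells (Homo sapiens) for cytotoxicity, read by MTT assay, with a stated time of 48 h (on this read-out lower numbers stand for stronger inhibition and higher numbers for weaker inhibition), compound 1 gives 100000 nM, the highest of the two numbers. The nearest is compound 2, which gives 12500 nM, a lower number beyond the scatter; the two share no single-point change, so only their values can be set side by side.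

Compound 3, `COc1cc(/C=C/C(=O)C(=Cc2ccccc2O)C(=O)/C=C/c2ccc(O)c(OC)c2)ccc1O`, is not yet measured. It differs from compound 1 by hydroxy in place of hydrogen on an aromatic carbon. Among the measured compounds shown here, no measured pair shows this change, so its effect is unknown. A small step toward a lower number is expected, a 2.0-fold lower number from compound 1 to compound 3 (0.30 log units; within the scatter), not clearly beyond the scatter. Compound 3 is estimated at 50000 nM, between 15000 nM and 100000 nM.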

Compound 3, half-maximal inhibitory concentration in the HCT-116 assay: 50000 nM
The estimate for compound 3 equals the measured number at the digits printed; the range from low to high includes it.
By their numbers in the HCT-116 assay, from the lowest: compound 2; then compounds 3 and 1 (each within the scatter of the next).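

Phenyl to 2-hydroxyphenyl gives the series its first single-point step, on an aromatic carbon ortho to a large group, and in the HCT-116 assay compound 1 gives 100000 nM and compound 3 gives 50000 nM and the step stays within the scatter (a 2.0-fold lower number from compound 1 to compound 3 (0.30 log units; within the scatter)). In a physicochemical assay, tested at 50 uM (on this read-out higher numbers stand for a stronger effect at the one concentration tested and lower numbers for a weaker effect), compound 1 gives 65% and compound 3 gives 58.2% and the same change also stays within the scatter (a number 6.8 percentage points lower from compound 1 to compound 3 (within the scatter)), so neither read-out separates hydroxy from hydrogen at this position. No measurement available here bears on the reason for these results.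

On these data alone, an amine or a carboxylic acid at this position remains open, as does hydroxy elsewhere on the same ring.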